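The compounds below may be only part of what the source reports. "The series", "measured", "known", "first", "only" and "open" are said of these compounds alone.

Measured compounds:
compound 1, `CCOc1ccc(C(=O)/C=C/c2ccc(CC)cc2)cc1`: 210 nM
compound 2, `O=C(/C=C/c1ccc(Br)cc1)c1ccc(-n2ccnc2)cc1`: 320 nM
compound 3, `COc1ccc(C(=O)/C=C/c2ccc(O/N=C(\C)c3ccc(OC)cc3)cc2)cc1`: > 200 nM

Of the numbers given, compound 1 stands lowest in an assay on isolated protein for inhibition of Amine oxidase [flavin-containing] B (Homo sapiens) (a higher number here means a weaker inhibitor, a lower number a stronger inhibitor), with compound 2 close to it by a gap within the scatter, so no order between the two is claimed. The value of compound 3 in this assay is a limit of the assay rather than a number (the limit of > 200 nM in this assay, at which 1 of the 3 values shown sits). Compound 4, `CCOc1ccc(C(=O)/C=C/c2ccc(F)cc2)cc1`, has not been measured; it differs from compound 1 in one place: fluoro in place of ethyl on an aromatic carbon. For the measured compounds named here, no measured pair shows this change. The step from compound 1 to compound 4 is expected to be small, toward a somewhat weaker inhibitor at most, at the edge of the scatter: a 1.9-fold higher number from compound 1 to compound 4 (0.28 log units; within the scatter). Compound 4 is therefore estimated at 400 nM, within 150 nM to 1200 nM.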

Compound 4, half-maximal inhibitory concentration: 53 nM
For compound 4 the middle estimate is 7.5-fold (0.88 log units) above the measured one, and the stated range ends above it.
By their numbers in this assay, from the lowest: compound 4; then compounds 1 and 2 (each within the scatter of the next).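

In this assay, for the compounds shown here, fluoro in place of ethyl on an aromatic carbon, para to a large group, gives a 4.0-fold lower number from compound 1 to compound 4 (0.60 log units; beyond the scatter) and this is the only step here that can be read, one that lies beyond the scatter. It shows that this position is sensitive to its substituent, and that the group with fewer heavy atoms goes with the stronger inhibitor here. Nothing given here bears on the reason for this gain.

Going by these compounds, whether an amine or a carboxylic acid at this position would match fluoro remains open. So does whether the same change would have a like effect on the core of compound 2.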